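Removing the Pyrazole Methyl in a Sulfonylguanidine Series

This account rests on a few compounds, and the source may have more. Where it says the series, first, only, none or still open, it means among the compounds named here.

The measured compounds and their values in a functional assay on HCT-116 cells (Homo sapiens) for cytotoxicity, read by MTT assay, with a stated time of 72 h; a lower number here means a stronger inhibitor, a higher number a weaker inhibitor:
compound 1 `Cc1ccc(CSc2cc(Cl)c(C)cc2S(=O)(=O)/N=C(\N)n2nc(C)cc2-c2ccccc2)cc1`, 28000 nM;
compound 2 `Cc1cc(-c2ccccc2)n(/C(N)=N/S(=O)(=O)c2cc(C)c(Cl)cc2SCc2cccc(C(F)(F)F)c2)n1`, 19000 nM;
compound 3 `Cc1cc(-c2ccccc2)n(/C(N)=N/S(=O)(=O)c2cc(C)c(Cl)cc2SCc2ccccc2)n1`, 10000 nM.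

Compound 1 gives the highest number of the three in this assay; compound 2 lies within the scatter of it, while compound 3 sits beyond it, with a 2.8-fold lower number from compound 1 to compound 3 (0.45 log units; beyond the scatter).

Compound 4 `Cc1ccc(CSc2cc(Cl)c(C)cc2S(=O)(=O)/N=C(\N)n2nccc2-c2ccccc2)cc1` differs from compound 1 by hydrogen in place of methyl on an aromatic carbon. Among the compounds with values here, no measured step alters this ring, so only the formal parallel of a 2.8-fold lower number from compound 1 to compound 3 (0.45 log units; beyond the scatter), also hydrogen in place of methyl on an aromatic carbon, bears on it; that step was modest. Compound 4 is therefore expected to give a number near that of compound 1, perhaps somewhat lower, with a 1.6-fold lower number from compound 1 to compound 4 (0.19 log units; within the scatter). The estimate for compound 4 in this assay is 18000 nM, in the range 7000 nM to 50000 nM.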

Compound 4, half-maximal inhibitory concentration: 14000 nM
Estimate against measurement, compound 4: 1.3-fold (0.11 log units) above, within the range that was stated.
By their numbers in this assay, from the lowest: compounds 3, 4, 2 and 1 (each within the scatter of the next, the first and the last beyond it).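

In this assay, hydrogen in place of methyl on the five-membered aromatic ring with 2 nitrogen gives a 2.0-fold lower number from compound 1 to compound 4 (0.30 log units; within the scatter), the only step shown at this ring. Thus the methyl on this carbon can be lost without a step beyond the scatter, whereas the formally identical change elsewhere, a 2.8-fold lower number from compound 1 to compound 3 (0.45 log units; beyond the scatter), lies beyond it. Nothing available explains this result.

On these data alone, whether an amine or an ethyl group on this carbon would move the number remains open. So does whether the same change would give a similar step on compound 2 or compound 3.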